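The compounds below may be only part of what the source reports. "The series", "measured", "known", "first", "only" and "open" are said of these compounds alone.

Measured so far:
compound 1 `CN(C)CCNc1ccnc2cc(OCc3ccc(F)cc3)ccc12` — 890 nM
compound 2 `CCCCOc1ccc2c(Cl)ccnc2c1` — 3610 nM
compound 3 `Clc1ccnc2cc(OCc3ccccc3)ccc12` — 5170 nM

All three numbers come from a functional assay on BGC-823 cells (Homo sapiens) for cytotoxicity, read by MTT assay, with a stated time of 48 h; on this read-out lower numbers stand for stronger inhibition and higher numbers for weaker inhibition. On them compound 1 stands lowest; the nearest is compound 2, the furthest compound 3, and both gaps lie beyond the scatter. Going by the values given here, compound 2 and compound 3 differ from compound 1 in more than one place, so no single step links either of them to it.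

Compound 4 `C=CCOc1ccc2c(NCCN(C)C)ccnc2c1` is not yet measured. Its difference from compound 1 is vinyl in place of 4-fluorophenyl on a saturated chain carbon bound to an oxygen on an aromatic ring; cut one bond further out, this reads 4-fluorobenzyl to allyl. Among the compounds with values here, the only measured step at the same place is a 1.4-fold higher number from compound 2 to compound 3 (0.16 log units; within the scatter), which exchanged a chain for an aromatic ring on the carbon bound to the ether oxygen and moved the number only within the scatter. That step runs in the opposite sense to the present change and sits on a core carrying a different group elsewhere, so it is a weak guide. On its evidence no step beyond the scatter is expected in this assay, in either direction. For compound 4 the expected value in this assay is 1200 nM, with a range from 450 nM to 3200 nM. This estimate corresponds to an expected step of a 1.3-fold higher number from compound 1 to compound 4 (0.13 log units; within the scatter).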

Compound 4, half-maximal inhibitory concentration: 1360 nM
Beside the measured number, compound 4's estimate is 1.1-fold (0.05 log units) below it; measured number inside the range.
By their numbers in this assay, from the lowest: compounds 1 and 4 (each within the scatter of the next); then compounds 2 and 3 (each within the scatter of the next).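

In this assay the step of a 1.5-fold higher number from compound 1 to compound 4 (0.18 log units; within the scatter) stays within the scatter, although 4-fluorobenzyl gives way to allyl and the aromatic ring and the fluorine leave the saturated chain carbon bound to the ether oxygen. On the core of compound 1, this place therefore tolerates a large change in the group without a readable shift, which agrees with the step of a 1.4-fold higher number from compound 2 to compound 3 (0.16 log units; within the scatter) on a core carrying a different group elsewhere, so both steps at this place, one in each sense between a chain and an aromatic ring, lie within the scatter. No measurement bears on why the number holds across this change.

The compounds shown do not separate the contribution of the fluorine from that of the phenyl ring, and they offer no step at this place beyond the scatter. As far as these compounds go, whether a longer chain, a terminal amine or a carboxylic acid on this carbon would move the number beyond the scatter stays open, as does how far the tolerance seen here carries over to other groups on the shared core.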